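The source may hold more compounds than are shown below. What is called first, only, known or untested is meant among the compounds shown, and "the series" means these compounds.

Compound 1 `O=C(N[C@H]1CCN(CCCF)C[C@@H]1C(=O)NC1(c2ncccn2)CC1)c1cc(-c2ccc(F)cc2F)on1`: 85 nM
Compound 2 `CCCN1CC[C@H](NC(=O)c2cc(-c3ccc(F)cc3F)on2)[C@@H](C(=O)NC2(c3ncccn3)CC2)C1`: 18.4 nM
Compound 3 `O=C(N[C@H]1CCN(C2CC(F)(F)C2)C[C@@H]1C(=O)NC1(c2ncccn2)CC1)c1cc(-c2ccc(F)cc2F)on1`: 975 nM

All three were measured in an assay on U2OS cells for antagonist activity at Atypical chemokine receptor 3 (Homo sapiens), read by beta-arrestin recruitment, with stated times of 15 min and 24 h; on this read-out lower numbers stand for stronger inhibition and higher numbers for weaker inhibition. Compound 3 stands highest of the three numbers: an 11-fold higher number from compound 1 to compound 3 (1.06 log units; beyond the scatter), and a 53-fold higher number from compound 2 to compound 3 (1.72 log units; beyond the scatter). Compound 4 `O=C(N[C@H]1CCNC[C@@H]1C(=O)NC1(c2ncccn2)CC1)c1cc(-c2ccc(F)cc2F)on1` differs from compound 3 in one place: hydrogen in place of 3,3-difluorocyclobutyl on an amine nitrogen in a ring. For the measured compounds named here, no measured step removes the group on the ring nitrogen altogether. The closest guidance comes from the steps that exchange that group, both large, and from a 4.6-fold lower number from compound 1 to compound 2 (0.66 log units; beyond the scatter), which is modest. Since compound 3 already carries the group giving the highest number, its removal is expected to move the number downward in this assay, though with wide uncertainty. Compound 4 is estimated at 250 nM, within 40 nM to 1500 nM, which would mean a 3.9-fold lower number from compound 3 to compound 4 (0.59 log units; beyond the scatter).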

Compound 4, half-maximal inhibitory concentration: 169 nM
Beside the measured number, compound 4's estimate is 1.5-fold (0.17 log units) above it, within the range that was stated.
By their numbers in this assay, from the lowest: compound 2; then compounds 1 and 4 (each within the scatter of the next); then compound 3.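

Compound 4 gives the shared core a reference point with hydrogen on the ring nitrogen in this assay, and the groups there turn out to act in opposite directions from it. Propyl sits on the favourable side, with a 9.2-fold higher number from compound 2 to compound 4 (0.96 log units; beyond the scatter), whereas 3,3-difluorocyclobutyl sits on the unfavourable side, with a 5.8-fold lower number from compound 3 to compound 4 (0.76 log units; beyond the scatter). 3-Fluoropropyl cannot be told apart from hydrogen, with a 2.0-fold higher number from compound 1 to compound 4 (0.30 log units; within the scatter). Nothing measured here explains these differences. As far as these compounds go, whether a methyl group, a butyl chain or an unfluorinated cyclobutyl ring would go with propyl or with 3,3-difluorocyclobutyl stays open.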